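The compounds below may be only part of what the source reports. "The series", "measured", "known", "first", "only" and "open" are said of these compounds alone.

Measured compounds:
Compound 1 `COc1c(N2CC[C@@H](CO)C2)c(F)cc2c(=O)c(C(=O)O)cn(Cc3ccc(-c4ccccc4)cc3)c12`, in an assay on isolated protein for inhibition of DNA topoisomerase 1 (Homo sapiens), with a stated time of 15 min, tested at 200 uM (a lower number here means less inhibition, a higher number more inhibition at the concentration tested (going by the name of the read-out)), compound 1 gives 10%.
Compound 2 `CNC[C@@H]1CCN(c2cc3c(cc2F)c(=O)c(C(=O)O)cn3Cc2ccc(-n3cccn3)cc2)C1`, in this assay compound 2 gives 10%.

Compound 2 stands level with compound 1 at the digits shown; the two values lie within the scatter of each other, so no order between them can be drawn. Among the compounds with values here, no pair of measured compounds differing in one place is available, so no measured step is known here.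

Compound 3 `O=C(O)c1cn(Cc2ccc(-n3cccn3)cc2)c2cc(NC[C@@H]3CCNC3)c(F)cc2c1=O` is the next compound. It differs from compound 2 in one place: ((pyrrolidin-3-yl)methyl)amino in place of 3-((methylamino)methyl)pyrrolidin-1-yl on an aromatic carbon. With both measured compounds at the same level in this assay, the step from compound 2 to compound 3 is expected to be small, with no direction beyond the scatter: no change at the digits printed from compound 2 to compound 3 (within the scatter). Compound 3 is therefore estimated at 10% in this assay, with a range from 0% to 25%, because compound 2 gives 10%.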

Compound 3, a percentage reported as inhibition, at one concentration (the size of the read-out at that concentration, not a potency): 10%
Beside the measured number, compound 3's estimate shows no gap at the digits printed, within the range that was stated.
By their numbers in this assay, from the lowest: compounds 1, 2 and 3 (each within the scatter of the next).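

In this assay, putting ((pyrrolidin-3-yl)methyl)amino in place of 3-((methylamino)methyl)pyrrolidin-1-yl, on the aromatic carbon ortho to a fluoro group, gives no change at the digits printed from compound 2 to compound 3 (within the scatter). Within the data shown here, this is the first measured step at this position, and it shows that the read-out at the tested concentration does not separate these two groups, although one is joined to the aromatic carbon through the ring nitrogen of the pyrrolidine and the other through an amino group. Nothing available explains this result.

On these data alone, it remains open whether a different group on this aromatic carbon, such as piperazin-1-yl or a longer aminoalkyl chain, would read differently. As far as these compounds go, it is also open whether the same exchange would give the same result on the core of compound 1.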